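The compounds below may be only part of what the source reports. "The series", "measured", "known", "first", "only" and "open" are said of these compounds alone.

Working notes on the series. In a functional assay on MCF7 cells (Homo sapiens) for antiproliferative activity, read by MTT assay (on this read-out higher numbers stand for weaker inhibition and lower numbers for stronger inhibition), compound 1 (`COc1cc2c(Oc3ccc(NC(=O)Nc4ccccc4)cc3)ccnc2cc1OCCCCCCC(=O)NO`) gives 1040 nM, compound 2 (`COc1cc2c(Oc3ccc(NC(=O)Nc4cccc(C)c4)cc3)ccnc2cc1OCCCCCCC(=O)NO`) gives 1240 nM and compound 3 (`COc1cc2c(Oc3ccc(NC(=O)Nc4ccc(OC(F)(F)F)cc4)cc3)ccnc2cc1OCCCCCCC(=O)NO`) gives 3200 nM. Compound 3 therefore stands highest of the three numbers, and so shows the weakest inhibition here.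

The next compound is compound 4 (`COc1cc2c(Oc3ccc(NC(=O)Nc4ccc(C(F)(F)F)cc4Cl)cc3)ccnc2cc1OCCCCCCC(=O)NO`), with 2-chloro-4-(trifluoromethyl)phenyl in place of 4-(trifluoromethoxy)phenyl on an amide-type nitrogen.

Three measured steps change the same group on that nitrogen. The first is a 1.2-fold higher number from compound 1 to compound 2 (0.08 log units; within the scatter), the second 3.1-fold higher number from compound 1 to compound 3 (0.49 log units; beyond the scatter) and the third 2.6-fold higher number from compound 2 to compound 3 (0.41 log units; beyond the scatter). The largest of these is thus only modest. Among the compounds with values here, no measured compound carries a chloro or trifluoromethyl substituent, so the direction of any change is open.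

In this assay, no shift beyond the scatter is expected, and the estimated step is a 1.1-fold lower number from compound 3 to compound 4 (0.03 log units; within the scatter). The estimate for compound 4 is 3000 nM, with an expected range of 1300 nM to 7000 nM.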

Compound 4, half-maximal inhibitory concentration: 500 nM
Compound 4: the middle estimate sits 6.0-fold (0.78 log units) above what was measured; measured number below the stated range.
By their numbers in this assay, from the lowest: compound 4; then compounds 1 and 2 (each within the scatter of the next); then compound 3.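

In this assay, within the data shown here, the group on the amide-type nitrogen can lower the number as well as raise it: the earlier steps here gave no fall beyond the scatter, whereas this change gives a 6.4-fold lower number from compound 3 to compound 4 (0.81 log units; beyond the scatter), alongside a 2.5-fold lower number from compound 2 to compound 4 (0.39 log units; beyond the scatter) and a 2.1-fold lower number from compound 1 to compound 4 (0.32 log units; beyond the scatter). Compound 4 therefore shows the strongest inhibition of the four, and since the entering and leaving groups both count 11 heavy atoms, heavy-atom count alone does not order them. Nothing available here accounts for the fall in the number.

The chloro and trifluoromethyl substituents enter together, so the compounds shown cannot assign the change to either one, and a phenyl carrying only one of them would separate the two. Going by these compounds, whether a nitrile or an amine on that ring would also lower the number remains open.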